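Butyl on the ring amine of compound 3

This account rests on a few compounds, and the source may have more. Where it says the series, first, only, none or still open, it means among the compounds named here.

Values so far in a functional assay on A549 cells (Homo sapiens) for cytotoxicity, read by MTT assay, with a stated time of 72 h; a higher number here means a weaker inhibitor, a lower number a stronger inhibitor
compound 1 `O=C1c2c[n+]([O-])c3ccccc3c2C(=O)c2c1c1ccccc1n2CCCCn1ccnc1` gives 170 nM
compound 2 `O=C1c2c[n+]([O-])c3ccccc3c2C(=O)c2c1c1ccccc1n2CCN1CCCC1` gives 410 nM
compound 3 `O=C1c2c[n+]([O-])c3ccccc3c2C(=O)c2c1c1ccccc1n2CCCCN1CCNCC1` gives 540 nM

Compound 3 sits level with its nearest neighbour: the data show a 1.3-fold higher number from compound 2 to compound 3 (0.12 log units; within the scatter) and no real separation. Its distance from the remaining compound is larger, with a 3.2-fold higher number from compound 1 to compound 3 (0.50 log units; beyond the scatter) as the measured gap.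

Compound 4 `CCCCN1CCN(CCCCn2c3c(c4ccccc42)C(=O)c2c[n+]([O-])c4ccccc4c2C3=O)CC1` differs from compound 3 in one place butyl in place of hydrogen on an amine nitrogen in a ring with butyl in place of hydrogen on an amine nitrogen in a ring. Going by the values given here, no measured step makes this change. The closest evidence is the swapping of end groups in the series, which gave a 2.4-fold higher number from compound 1 to compound 2 (0.38 log units; beyond the scatter) as a modest step and a 3.2-fold higher number from compound 1 to compound 3 (0.50 log units; beyond the scatter) as another. From compound 3 a similarly small move is therefore expected, probably none beyond the scatter. The estimated step is a 1.4-fold lower number from compound 3 to compound 4 (0.13 log units; within the scatter) and its direction is only weakly expected. The estimate for compound 4 is 400 nM with an expected range of 150 nM to 1100 nM in this read-out.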

Compound 4, half-maximal inhibitory concentration: 550 nM
Compound 4: middle estimate off by 1.4-fold (0.14 log units), on the low side, within the range that was stated.
By their numbers in this assay, from the lowest: compound 1; then compounds 2, 3 and 4 (each within the scatter of the next).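

In this assay, going by these compounds alone, the earlier compounds exchanged whole end groups, whereas this change adds butyl on an amine nitrogen in a ring and leaves the rest of the piperazin-1-yl group in place, with no separation from the parent (a 1.0-fold higher number from compound 3 to compound 4 (0.01 log units; within the scatter)). The 4-butylpiperazin-1-yl compound also stays level with the pyrrolidin-1-yl compound (a 1.3-fold higher number from compound 2 to compound 4 (0.13 log units; within the scatter)) and remains apart from the 1H-imidazol-1-yl compound (a 3.2-fold higher number from compound 1 to compound 4 (0.51 log units; beyond the scatter)), so hydrogen and butyl on this nitrogen cannot be told apart here. Nothing on hand explains why the number holds level.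

Butyl is the only group shown on this nitrogen, so it remains open whether methyl, benzyl or acetyl there would also leave the number level. Also open, going by these compounds, is whether 4-butylpiperazin-1-yl would behave the same on a shorter or longer chain.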